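Removing the Methoxy Group from the Benzyl Substituent

This account rests on a few compounds, and the source may have more. Where it says the series, first, only, none or still open, it means among the compounds named here.

In a functional assay on BT-474 cells (Homo sapiens) for inhibition, read by fluorescence, with a stated time of 72 h (a lower number here means a stronger inhibitor of growth, a higher number a weaker inhibitor of growth), compound 1 `COc1ccc(Cn2cnc3c(Nc4cccc(Cl)c4)nc(N[C@H]4CC[C@H](N)CC4)nc32)cc1` gives 8200 nM and compound 2 `CCCCn1cnc2c(Nc3cc(OC)cc(OC)c3)nc(N[C@H]3CC[C@H](N)CC3)nc21` gives 15600 nM on the same read-out. These two numbers lie within the usual scatter of each other, so compound 1 cannot be placed ahead of or behind compound 2.

Compound 3 `N[C@H]1CC[C@H](Nc2nc(Nc3cccc(Cl)c3)c3ncn(Cc4ccccc4)c3n2)CC1` has not yet been measured. It is reached from compound 1 by a single change, hydrogen in place of methoxy on an aromatic carbon, para to a large group, which turns 4-methoxybenzyl to benzyl. The difference hydrogen in place of methoxy on an aromatic carbon is the only one between the two structures.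

Within the data shown here, no measured pair of compounds shows this change alone, so its size has to be judged without a direct precedent. In this assay no step beyond the scatter is expected, and neither direction is favoured. The estimated move a 1.0-fold lower number from compound 1 to compound 3 (0.01 log units; within the scatter) is expected to be small. For compound 3 the expected value is 8000 nM with a range from 3500 nM to 18000 nM in this estimate.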

Compound 3, concentration for 50% growth inhibition: 10200 nM
Compound 3: the middle estimate sits 1.3-fold (0.11 log units) below what was measured; measured number inside the range.
By their numbers in this assay, from the lowest: compounds 1, 3 and 2 (each within the scatter of the next).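

Among these compounds, the step gives the first direct reading at this position: in this assay, replacing methoxy with hydrogen on the aromatic carbon, which turns 4-methoxybenzyl to benzyl, gives a 1.2-fold higher number from compound 1 to compound 3 (0.09 log units; within the scatter) and so cannot be told apart from repeat measurement. In this pair, the loss of the methoxy group, with its two heavy atoms and one hydrogen-bond acceptor, leaves no mark that this read-out can resolve, although this is a single pair and says nothing about the same change in another structure. Nothing at hand accounts for this result.

From the compounds shown here alone, it remains open whether an amine, a carboxylic acid or a longer chain, placed on the same aromatic carbon para to a large group, would give a step beyond the scatter. Going by these compounds, the part played by the benzyl group as a whole is also open, since compound 2 differs from compound 1 and compound 3 in more than one place and offers no clean comparison with either.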